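The compounds below may be only part of what the source reports. "The series", "measured", "known", "first", "only" and "open" are said of these compounds alone.

Measured so far in a functional assay on PC-3 cells (Homo sapiens) for inhibition, read by MTT assay, with a stated time of 48 h; a lower number here means a stronger inhibitor, a higher number a weaker inhibitor
compound 1 (`CCN1CCN(C(=S)SCCCOc2ccc3c(=O)c(-c4ccc(OC)cc4)coc3c2)CC1`) gives 7080 nM
compound 2 (`COc1ccc(-c2coc3cc(OCCCSC(=S)N4CCN(Cc5ccccc5)CC4)ccc3c2=O)cc1`) gives 14900 nM
compound 3 (`COc1ccc(-c2coc3cc(OCCCSC(=S)N4CCN(C(C)=O)CC4)ccc3c2=O)cc1`) gives 4310 nM

Compound 3 cannot be told apart from the ethyl compound (a 1.6-fold lower number from compound 1 to compound 3 (0.22 log units; within the scatter)) but stands clear of the benzyl compound (a 3.5-fold lower number from compound 2 to compound 3 (0.54 log units; beyond the scatter)). Compound 4 (`COc1ccc(-c2coc3cc(OCCCSC(=S)N4CCN(C(=O)OC(C)(C)C)CC4)ccc3c2=O)cc1`) has tert-butoxy in place of methyl on a carbonyl carbon. Among the measured compounds shown here, no measured step makes this exact change. The nearest guides are those two steps and the change from methyl to phenyl (a 2.1-fold higher number from compound 1 to compound 2 (0.32 log units; beyond the scatter)), where the larger group went with the higher number. A small move to a higher number is therefore expected, scarcely beyond the scatter (a 1.4-fold higher number from compound 3 to compound 4 (0.14 log units; within the scatter)). The estimate for compound 4 is 6000 nM, with an expected range from 2500 nM to 15000 nM.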

Compound 4, half-maximal inhibitory concentration: 1970 nM
Estimate against measurement, compound 4: 3.0-fold (0.48 log units) above; measured number outside the range, below it.
By their numbers in this assay, from the lowest: compound 4; then compounds 3 and 1 (each within the scatter of the next); then compound 2.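

In this assay, the larger group on this carbonyl carbon goes with a lower number, tert-butoxy in place of methyl giving (a 2.2-fold lower number from compound 3 to compound 4 (0.34 log units; beyond the scatter)), so the link between a larger group and a higher number seen with benzyl does not extend to this change. Tert-butoxycarbonyl on the amine nitrogen in the ring also stands clear of benzyl (a 7.6-fold lower number from compound 2 to compound 4 (0.88 log units; beyond the scatter)) and ethyl (a 3.6-fold lower number from compound 1 to compound 4 (0.56 log units; beyond the scatter)), making compound 4 the strongest of the four. No evidence at hand explains this result.

The compounds shown leave open whether the lower number follows the oxygen bound to the carbonyl or the branched tert-butyl part. A methoxy group on the same carbonyl carbon would separate the two.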